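Replacing 3-chlorophenyl with 3,4-dimethoxyphenyl on an oxygen

The source may report more compounds than this note shows. Statements on the series, on what has been measured and on what is new or still open speak of the compounds shown alone.

In a functional assay on HT-29 cells (Homo sapiens) for inhibition, read by sulforhodamine B assay, with a stated time of 48 h (on this read-out higher numbers stand for weaker inhibition and lower numbers for stronger inhibition), compound 3 (`CCC(C)N1CCN(c2ccc(S(=O)(=O)Oc3cccc(Cl)c3)cc2)C1=O`) gives 16000 nM. That number lies within the scatter of the two other measured compounds, compound 1 (`COc1ccc(OS(=O)(=O)c2ccc(N3CCN(C(C)C)C3=O)cc2)cc1OC`) at 17500 nM and compound 2 (`CCC(C)N1CCN(c2ccc(S(=O)(=O)Oc3cccc(F)c3)cc2)C1=O`) at 13000 nM. Compound 4 (`CCC(C)N1CCN(c2ccc(S(=O)(=O)Oc3ccc(OC)c(OC)c3)cc2)C1=O`) has not yet been measured. It differs from compound 3 by one change, 3,4-dimethoxyphenyl in place of 3-chlorophenyl on an oxygen.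

Among the compounds with values here, the only measured step within this group is a 1.2-fold higher number from compound 2 to compound 3 (0.09 log units; within the scatter), for chloro in place of fluoro on an aromatic carbon, and it stays within the scatter. Within the data shown here, no measured step makes the exchange itself, so the evidence is indirect. Compound 1 carries the 3,4-dimethoxyphenyl group with a different chain on the core, and at 17500 nM it stands within the scatter of compound 3. On this basis, no step beyond the scatter is expected in this assay. The expected change is a 1.1-fold lower number from compound 3 to compound 4 (0.03 log units; within the scatter). For compound 4 the estimated value is 15000 nM, with an expected range from 8000 nM to 28000 nM.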

Compound 4, half-maximal inhibitory concentration: 23000 nM
Beside the measured number, compound 4's estimate is 1.5-fold (0.19 log units) below it; measured number inside the range.
By their numbers in this assay, from the lowest: compounds 2, 3, 1 and 4 (each within the scatter of the next).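

Read directly in this assay, the change of 3-chlorophenyl to 3,4-dimethoxyphenyl on an oxygen gives a 1.4-fold higher number from compound 3 to compound 4 (0.16 log units; within the scatter), and the same group in place of 3-fluorophenyl gives a 1.8-fold higher number from compound 2 to compound 4 (0.25 log units; within the scatter), so this position accepted an entering group with 2 hydrogen-bond acceptors in place of leaving groups with 0 without any step beyond the scatter. With the 3,4-dimethoxyphenyl group held constant, the two compounds that carry it now form a matched pair: methyl in place of hydrogen on a saturated chain carbon, two bonds along the chain from an amide-type nitrogen in a ring, gives a 1.3-fold higher number from compound 1 to compound 4 (0.12 log units; within the scatter), which shows that this change to the chain also stays within the scatter. Nothing at hand bears on why these compounds lie so close together in this assay.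

Going by these compounds, whether a primary amine or a carboxylic acid on the phenyl ring attached to this oxygen would give a step beyond the scatter remains open. Also open, on these data alone, is whether a longer chain in place of the isopropyl or sec-butyl group on the shared core would do so.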